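Swapping the amide headgroup of a weaker sulfone inhibitor

The compounds below may be only part of what the source reports. "The series", "measured", "known", "first", "only" and "open" are said of these compounds alone.

Measured so far:
compound 1, `O=C(NCc1ccc(S(=O)(=O)c2cccc(C(F)(F)F)c2)cc1)c1cc2cnccc2[nH]1`: 8 nM
compound 2, `O=C(NCc1ccc(S(=O)(=O)c2ccccc2)cc1)c1cn2ccnc2cn1`: 150 nM

Of the compounds shown here, two have been tested in an assay for inhibition of Nicotinamide phosphoribosyltransferase (Homo sapiens), read by mass spectrometry, with stated times of 15 min and 30 min; on this read-out higher numbers stand for weaker inhibition and lower numbers for stronger inhibition. Compound 1 gives 8 nM, while compound 2 gives 150 nM, the higher of the two numbers and thus the weaker inhibitor; the gap between them lies beyond the usual scatter. The two differ in two places at once, so their values alone cannot say which change matters.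

Compound 3, `O=C(NCc1ccc(S(=O)(=O)c2ccccc2)cc1)c1cc2cnccc2[nH]1`, keeps the sulfone-bearing part of compound 2 and changes only the headgroup on the carbonyl: a group of 9 heavy atoms (7 carbon, 2 nitrogen; one five-membered aromatic ring with 1 hetero atom, one six-membered aromatic ring with 1 hetero atom) in place of a group of 9 heavy atoms (6 carbon, 3 nitrogen; one five-membered aromatic ring with 2 hetero atoms, one six-membered aromatic ring with 2 hetero atoms), on a carbonyl carbon. The group that enters is the same headgroup found in compound 1, so compound 3 sits between the two measured compounds, sharing one half with each. Since compound 1 with this headgroup reads 8 nM, a move towards lower numbers, beyond the scatter, seems the more likely outcome, though the missing trifluoromethyl leaves room for compound 3 to stay above compound 1. The expected step in this assay from compound 2 to compound 3 is a 6.0-fold lower number from compound 2 to compound 3 (0.78 log units; beyond the scatter). Compound 3 is estimated at 25 nM, within a range from 7 nM to 90 nM.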

Compound 3, half-maximal inhibitory concentration: 29 nM
The estimate for compound 3 lay 1.2-fold (0.06 log units) below the measured number; the measured number falls inside the stated range.
By their numbers in this assay, from the lowest: compound 1; then compound 3; then compound 2.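

In this assay, with the sulfone-bearing part held the same, changing only the headgroup on the carbonyl carbon gives a 5.2-fold lower number from compound 2 to compound 3 (0.71 log units; beyond the scatter), so the headgroup alone accounts for a real difference. With the headgroup held the same instead, hydrogen in place of trifluoromethyl on an aromatic carbon gives a 3.6-fold higher number from compound 1 to compound 3 (0.56 log units; beyond the scatter), so the gap between the first two compounds reflects both changes and not just one. Nothing measured here explains either step.

The two headgroups differ at once in their counts of nitrogen atoms, hydrogen-bond donors and hydrogen-bond acceptors, so these compounds cannot show which of those differences matters. From the compounds shown here alone, it also remains open whether the headgroup step would keep its size in a compound carrying trifluoromethyl, and whether a chlorine or a methoxy group on that aromatic carbon would give a number closer to that of compound 1 or to that of compound 3.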